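The source may report more compounds than this note shows. Statements on the series, on what has been measured and on what is new or still open speak of the compounds shown alone.

- Compound 1 `COc1ccc(-c2cc3c(OC)ccc(OC)c3nc2O)cc1` gives 10000 nM
- Compound 2 `COc1cc(OC)c2cc(-c3ccc(OCc4ccccc4)cc3)c(O)nc2c1` gives 10000 nM
- Compound 3 `COc1ccc(-c2cc3c(OC)cc(OC)cc3n(CC#N)c2=O)cc1` gives 10000 nM

All three values come from a functional assay on LoVo cells (Homo sapiens) for cytotoxicity, read by colorimetric assay and MTT assay (a higher number here means a weaker inhibitor, a lower number a stronger inhibitor), and sit level with one another. With compounds 1 and 2 beside it, compound 3 stands at 10000 nM with no difference beyond the scatter. Compound 4 `COC(=O)CCn1c(=O)c(-c2ccc(OC)cc2)cc2c(OC)cc(OC)cc21` differs from compound 3 in one place (methoxycarbonyl)methyl in place of cyano on a saturated chain carbon bound to an aromatic nitrogen with (methoxycarbonyl)methyl in place of cyano on a saturated chain carbon bound to an aromatic nitrogen. For the measured compounds named here, no two measured compounds differ in only one place, so no measured step can guide the expectation. The three values show no spread, so in this assay no change beyond the scatter is expected in either direction. The expected size of no change at the digits printed from compound 3 to compound 4 (within the scatter) stays within the scatter. Compound 4 is estimated at 10000 nM with a likely range from 3000 nM to 20000 nM as its span.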

Compound 4, half-maximal inhibitory concentration: 10000 nM
Compound 4: middle estimate and measured number agree at the digits printed, within the range that was stated.
By their numbers in this assay, from the lowest: compounds 1, 2, 3 and 4 (each within the scatter of the next).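

In this assay, putting (methoxycarbonyl)methyl in place of cyano on a saturated chain carbon bound to an aromatic nitrogen gives no change at the digits printed from compound 3 to compound 4 (within the scatter). This is the first step among these compounds that can be read, and it shows that five heavy atoms in place of two at this position leave the value where it was. Nothing measured here offers an explanation for this result.

Going by these compounds, whether an amine or a carboxylic acid on this chain would read differently remains open. So does whether any group at this position can move the value at all.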